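Hydroxy to Methoxy on the Core of Compound 1

The source may report more compounds than this note shows. Statements on the series, on what has been measured and on what is new or still open speak of the compounds shown alone.

Compound 1 `O=C(Nc1cccc(-n2cc(-c3ccncc3)c(-c3cc(O)cc(Cl)c3)n2)c1)Nc1ccc(Cl)c(C(F)(F)F)c1` and compound 2 `O=C(Nc1cccc(-n2cc(-c3ccncc3)c(-c3cc(O)cc(Cl)c3)n2)c1)Nc1ccc(Cl)c(Cl)c1` differ only in a chloro in place of a trifluoromethyl on an aromatic carbon. In a functional assay on COLO 205 cells (Homo sapiens) for inhibition, read by sulforhodamine B assay, with a stated time of 48 h, tested at 100 uM (on this read-out higher numbers stand for a weaker effect at the one concentration tested and lower numbers for a stronger effect), compound 1 gives -77%, and in this assay compound 2 gives -88%. Compound 1 therefore stands highest of the two numbers measured, its nearest neighbour being compound 2, separated by a number 11 percentage points lower from compound 1 to compound 2 (beyond the scatter). The compound now in question, compound 3 `COc1cc(Cl)cc(-c2nn(-c3cccc(NC(=O)Nc4ccc(Cl)c(C(F)(F)F)c4)c3)cc2-c2ccncc2)c1`, departs from compound 1 at a different group: methyl in place of hydrogen on an oxygen on an aromatic ring, which one bond further out reads hydroxy to methoxy, or 3-chloro-5-hydroxyphenyl to 3-chloro-5-methoxyphenyl. Going by the values given here, no measured step touches this oxygen; the single step available, a number 11 percentage points lower from compound 1 to compound 2 (beyond the scatter), concerns a different group and was modest. There is thus no basis for expecting a shift in this assay beyond the scatter in either direction. Compound 3 is accordingly estimated to give -77% in this assay, within -95% to -50%, which corresponds to an expected no change at the digits printed from compound 1 to compound 3 (within the scatter).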

Compound 3, a percentage reported as activity, at one concentration (the size of the read-out at that concentration, not a potency): -79%
Estimate against measurement, compound 3: 2 percentage points above; the range from low to high includes it.
By their numbers in this assay, from the lowest: compounds 2, 3 and 1 (each within the scatter of the next, the first and the last beyond it).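

At the oxygen on the aromatic ring, methyl in place of hydrogen leaves the result in this assay within the scatter, with a number 2 percentage points lower from compound 1 to compound 3 (within the scatter). Going by these compounds alone, this is the first reading at this oxygen, since compound 1 and compound 2 differ only in trifluoromethyl and chloro, and it shows that, on the core of compound 1, the hydrogen of the hydroxy group can be replaced by methyl with no shift beyond the scatter at the one concentration tested. No measurement bears on why the two compounds read alike here.

Going by these compounds, whether this tolerance extends to a longer chain on the oxygen, as in ethoxy, or to an amine in place of the hydroxy group remains open, as does whether methoxy would read the same alongside the chloro group of compound 2. On these data alone, a read-out at a single concentration is also no measure of potency, so it remains open whether compound 1 and compound 3 would separate at other concentrations.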